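Working notes on a small cytotoxicity series

A few compounds are considered here, and "the series" means these few. Any claim that something is new, unique, unknown or untested is made for them only; others in the source may bear on it.

Measured compounds:
compound 1, `O=c1ccc2cc(OCc3cc(-c4ccccc4Cl)no3)ccc2o1` — "not determined" (no result reported)
compound 2, `O=c1ccc2cc(OCc3cn(-c4ccccc4)nn3)ccc2o1` — 51500 nM

In a functional assay on HCT-116 cells (Homo sapiens) for cytotoxicity, read by MTT assay, with a stated time of 48 h (on this read-out higher numbers stand for weaker inhibition and lower numbers for stronger inhibition), compound 2 gives 51500 nM. In this assay, for the measured compounds named here, compound 1 gives "not determined" (no result reported), so compound 2 carries the only number in the set and there is no second value to set it against; no step between measured compounds exists.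

Compound 3, `O=c1ccc2cc(OCc3cn(-c4ccc([N+](=O)[O-])cc4)nn3)ccc2o1`, is not yet measured. It differs from compound 2 in one place: nitro in place of hydrogen on an aromatic carbon of the six-membered aromatic ring of carbon only, para to a large group. Going by the values given here, with no measured step to lean on, the expectation is a change of no more than the usual scatter in either direction, so a 1.3-fold lower number from compound 2 to compound 3 (0.11 log units; within the scatter) is estimated as essentially flat. For compound 3 the estimate in this assay is 40000 nM, with a range from 10000 nM to 150000 nM.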

Compound 3, half-maximal inhibitory concentration: 44300 nM
For compound 3 the middle estimate is 1.1-fold (0.04 log units) below the measured one, within the range that was stated.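

In this assay the series gains its first readable step, which is a 1.2-fold lower number from compound 2 to compound 3 (0.07 log units; within the scatter) for nitro in place of hydrogen on an aromatic carbon. At this place, para to a large group, phenyl to 4-nitrophenyl adds a group of 3 heavy atoms with 2 hydrogen-bond acceptors while the read-out stays within the scatter, so this single substitution gives no sign of a change in cytotoxicity. No evidence accompanies the result that would explain this outcome.

The compounds shown leave open whether a different group at the same place, such as an amine, a carboxylic acid or a longer chain, would move the number in this assay beyond the scatter. One step at one place supports no pattern across the series.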